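Adding a third methoxy to the aryl ring of compound 3

The compounds below may be only part of what the source reports. "The series", "measured", "known", "first", "only" and "open" are said of these compounds alone.

Measured compounds, each with its result in a functional assay on KB cells (Homo sapiens) for antiproliferative activity, read by sulforhodamine B assay, with a stated time of 3 days; a higher number here means that more compound is needed for the effect, a lower number that less compound is needed:
- compound 1 `CCC1=C(O)c2c(oc(-c3ccccc3C)cc2=O)C(CC)(CC)C1=O`: 40.9 uM
- compound 2 `CCC1=C(O)c2c(oc(-c3ccc(OC)cc3C)cc2=O)C(CC)(CC)C1=O`: 20.9 uM
- compound 3 `CCC1=C(O)c2c(oc(-c3ccc(OC)c(OC)c3)cc2=O)C(CC)(CC)C1=O`: 14.7 uM

All three share the same bicyclic core and differ only in the substituents on the pendant aromatic ring. Compound 2 differs from compound 1 by methoxy in place of hydrogen on an aromatic carbon, and this gave a 2.0-fold lower number from compound 1 to compound 2 (0.29 log units; within the scatter). Compound 3 carries two methoxy groups and no methyl; the difference between its core and that of compound 1 is not broken down here. Compound 3 shows the lowest number of the three, though its gap to compound 2 stays within the scatter, and only its gap to compound 1 lies beyond it.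

Compound 4 `CCC1=C(O)c2c(oc(-c3ccc(OC)c(OC)c3OC)cc2=O)C(CC)(CC)C1=O` has not yet been measured in this assay. It differs from compound 3 by methoxy in place of hydrogen on an aromatic carbon. This is the same kind of change as from compound 1 to compound 2, but the surroundings differ: in compound 2 the new methoxy sits meta to a methyl group and para to the large group, whereas in compound 4 it sits ortho to the large group, ortho to a methoxy group and meta to a methoxy group.

Compound 4 is expected to give 10 uM, somewhere between 4 uM and 30 uM. This estimate rests on compound 3 with 14.7 uM and on the modest change seen as a 2.0-fold lower number from compound 1 to compound 2 (0.29 log units; within the scatter), so the expected step of a 1.5-fold lower number from compound 3 to compound 4 (0.17 log units; within the scatter) is small and likely within the scatter.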

Compound 4, concentration for half-maximal effect: 9.4 uM
For compound 4 the middle estimate is 1.1-fold (0.03 log units) above the measured one; low and high end bracket the measured number.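

In this assay, methoxy in place of hydrogen on an aromatic carbon gives a 1.6-fold lower number from compound 3 to compound 4 (0.19 log units; within the scatter), and the same change can be set beside its earlier appearance on another core: the same change on two cores in this assay, a 2.0-fold lower number (0.29 log units; within the scatter) from compound 1 to compound 2 and a 1.6-fold lower number (0.19 log units; within the scatter) from compound 3 to compound 4, 1.3-fold (0.10 log units) apart, within the scatter of two such steps. The two steps therefore agree as far as these data can tell, and nothing here suggests that the size of the change depends on which of the two aryl rings carries it. Each step on its own lies within the scatter, however, so the pair does not establish that methoxy truly lowers the number on either core, and two examples make no rule for the whole series.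

The compounds shown leave open whether a different group on the aromatic ring, such as an amine, a carboxylic acid, a fluorine or a longer chain like ethoxy, would move the number by more than the scatter. They also leave open whether changing the ethyl groups on the shared core would matter more than any of these changes to the pendant aromatic ring.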